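Fluoro placement on the anilide ring: compound 2 to compound 3

The compounds below may be only part of what the source reports. "The series", "measured", "known", "first", "only" and "open" are said of these compounds alone.

Values in a functional assay on MCF7 cells (Homo sapiens) for cytotoxicity, read by MTT assay, with a stated time of 72 h (on this read-out lower numbers stand for stronger inhibition and higher numbers for weaker inhibition), so far:
- compound 1 `Cc1nc2ccccn2c1-c1ccnc(NCc2ccc(C(=O)Nc3ccccc3N)cc2)n1` gives 2090 nM
- compound 2 `Cc1nc2ccccn2c1-c1ccnc(NCc2ccc(C(=O)Nc3cc(F)ccc3N)cc2)n1` gives 1000 nM
- compound 3 `Cc1nc2ccccn2c1-c1ccnc(NCc2ccc(C(=O)Nc3ccc(F)cc3N)cc2)n1` has not yet been measured

Compound 2 gives the lower of the two numbers at 1000 nM in this assay and stands nearest to compound 1 at 2090 nM on the higher side. The change to compound 3 is 2-amino-4-fluorophenyl in place of 2-amino-5-fluorophenyl on an amide-type nitrogen and the two structures have the same atoms, joined differently.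

For the measured compounds named here, one measured step bears on this change: a 2.1-fold lower number from compound 1 to compound 2 (0.32 log units; beyond the scatter) for fluoro in place of hydrogen on an aromatic carbon. That step is modest, though beyond the scatter, and it records adding a fluoro rather than changing its place. Going by the values given here, no measured pair shows such a change of place, so the direction stays open and no step beyond the scatter is expected in this assay here. The estimated move is a 1.1-fold higher number from compound 2 to compound 3 (0.04 log units; within the scatter) and it is expected to stay small. The expected value for compound 3 is 1100 nM within an estimated range from 450 nM to 2600 nM for now.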

Compound 3, half-maximal inhibitory concentration: 2400 nM
Beside the measured number, compound 3's estimate is 2.2-fold (0.34 log units) below it; the measured number falls inside the stated range.
By their numbers in this assay, from the lowest: compound 2; then compounds 1 and 3 (each within the scatter of the next).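

In this assay, for the compounds shown here, the change from 2-amino-5-fluorophenyl to 2-amino-4-fluorophenyl on the amide-type nitrogen gives a 2.4-fold higher number from compound 2 to compound 3 (0.38 log units; beyond the scatter); this is the first measured change of place, and with the atoms the same, the arrangement of the ring alone accounts for a modest step beyond the scatter. Set against a 2.1-fold lower number from compound 1 to compound 2 (0.32 log units; beyond the scatter), the step of a 1.1-fold higher number from compound 1 to compound 3 (0.06 log units; within the scatter) shows that fluoro in place of hydrogen does not give the same outcome at both places on this ring: only the 2-amino-5-fluorophenyl compound stands apart from the unsubstituted anilide, so the gain seen earlier cannot be read as a general effect of adding fluoro. Nothing at hand accounts for the difference between the two fluoro placements.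

As far as these compounds go, whether the same split between the two places holds for chloro, methyl or methoxy in place of fluoro remains open. Also open, from the compounds shown here alone, is whether a 2-amino-4,5-difluorophenyl group would follow compound 2, follow compound 3 or differ from both in this assay.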